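This account rests on a few compounds, and the source may have more. Where it says the series, first, only, none or still open, it means among the compounds named here.

Compound 1 `Cc1ccc(NC(=S)NC(=O)c2cn(-c3ccccc3)nc2-c2ccc(Cl)cc2)cc1`: 5980 nM
Compound 2 `Cc1ccc(-c2nn(-c3ccccc3)cc2C(=O)NC(=S)Nc2ccc(Cl)cc2)cc1`: 6210 nM

In a functional assay on MCF7 cells (Homo sapiens) for inhibition, read by CCK-8 assay, with a stated time of 48 h (on this read-out higher numbers stand for weaker inhibition and lower numbers for stronger inhibition), compound 1 gives 5980 nM and compound 2 gives 6210 nM; these two numbers lie within the scatter of each other, so compound 2 stands level with compound 1 rather than apart from it. Compound 3 `O=C(NC(=S)Nc1ccc(Cl)cc1)c1cn(-c2ccccc2)nc1-c1ccc(Cl)cc1` differs from compound 2 by chloro in place of methyl on an aromatic carbon. Among the compounds with values here, no step between measured compounds carries this change, so the expected step in this assay is a 1.0-fold lower number from compound 2 to compound 3 (0.01 log units; within the scatter), none beyond the scatter in either direction. Compound 3 is therefore expected to give 6000 nM in this assay, with a range from 2500 nM to 14000 nM.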

Compound 3, half-maximal inhibitory concentration: 5360 nM
For compound 3 the middle estimate is 1.1-fold (0.05 log units) above the measured one; measured number inside the range.
By their numbers in this assay, from the lowest: compounds 3, 1 and 2 (each within the scatter of the next).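

In this assay chloro in place of methyl gives a 1.2-fold lower number from compound 2 to compound 3 (0.06 log units; within the scatter) and, at the other place that carries a methyl, gives a 1.1-fold lower number from compound 1 to compound 3 (0.05 log units; within the scatter). The change from 4-methylphenyl to 4-chlorophenyl therefore leaves the number level at both places, so this read-out does not separate the two groups at either one. No measurement shown here bears on this result. Still open, on these data alone, is whether an amine, a carboxylic acid or a longer chain at this position would move the number beyond the scatter.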